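Sulfonamide substitution on the thiourea series: compound 3

The compounds below may be only part of what the source reports. "The series", "measured", "known", "first", "only" and "open" are said of these compounds alone.

Working notes on a small set sharing the same core. Compound 1 `O=C(Nc1ccccc1)Nc1ccc(S(=O)(=O)Nc2ccnc3cc(C(F)(F)F)ccc23)cc1` carries a urea on the aryl sulfonamide side; in a functional assay on MDA-MB-231 cells (Homo sapiens) for antiproliferative activity, read by sulforhodamine B assay, with a stated time of 48 h (a higher number here means a weaker inhibitor, a lower number a stronger inhibitor), compound 1 gives 52900 nM. Compound 2 `NS(=O)(=O)c1ccc(N/C(S)=N\c2ccnc3cc(C(F)(F)F)ccc23)cc1` replaces the urea link with a thiourea and keeps a primary sulfonamide; in this assay compound 2 gives 52900 nM, level with compound 1 at the digits shown and within the scatter, so no change between the two can be read. Among the measured compounds shown here, no step between measured compounds is available to guide the next change.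

Compound 3 `N=C(N)NS(=O)(=O)c1ccc(N/C(S)=N\c2ccnc3cc(C(F)(F)F)ccc23)cc1` differs from compound 2 only at the sulfonamide nitrogen: a group of 3 heavy atoms (1 carbon, 2 nitrogen; no ring) in place of a hydrogen atom, on a sulfonamide nitrogen. With both measured compounds sitting at the same value, nothing in the data points to a direction, and the expected step is no change at the digits printed from compound 2 to compound 3 (within the scatter), none beyond the scatter. Compound 3 is accordingly estimated at 52900 nM in this assay, expected to lie between 20000 nM and 110000 nM.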

Compound 3, half-maximal inhibitory concentration: "not active" (no number reported)
Nothing numeric was reported for compound 3; no gap can be computed for the estimate.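

Among the compounds shown here, compound 3 is reported as not active in this assay with no number given, so no step from compound 2 to compound 3 can be read. No measured evidence bears on this result. The compounds shown leave open how substitution on the sulfonamide nitrogen affects antiproliferative activity.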